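A few compounds are considered here, and "the series" means these few. Any claim that something is new, unique, unknown or untested is made for them only; others in the source may bear on it.

Compound 1 `COc1cc(C2=NNC(c3ccc(Cl)cc3)C2O)cc(OC)c1OC` and compound 2 `COc1cc(C2=NNC(c3ccc(F)cc3)C2O)cc(OC)c1OC` share one core, while compound 3 `COc1cc(-c2cc(-c3ccc(Cl)cc3)[nH]n2)cc(OC)c1OC` and compound 4 `COc1cc(-c2cc(-c3ccc(F)cc3)[nH]n2)cc(OC)c1OC` share another; the difference between the two cores is not broken down here. In a functional assay on SW-620 cells (Homo sapiens) for inhibition (on this read-out higher numbers stand for weaker inhibition and lower numbers for stronger inhibition), compound 1 gives 8410 nM, and compound 2 gives 5850 nM. The change from compound 1 to compound 2 is fluoro in place of chloro on an aromatic carbon, and it made a 1.4-fold lower number from compound 1 to compound 2 (0.16 log units; within the scatter). In this assay compound 3 gives 4960 nM; this number and those of compound 1 and compound 2 all lie within the scatter of one another, so no order among the three can be read from them. Compound 4 has not been measured. It differs from compound 3 by fluoro in place of chloro on an aromatic carbon, the same change as between compound 1 and compound 2, at a place described in the same words. Resting only on the earlier step of a 1.4-fold lower number from compound 1 to compound 2 (0.16 log units; within the scatter), the step expected here is a 1.3-fold lower number from compound 3 to compound 4 (0.12 log units; within the scatter), a small one. Compound 4 is therefore expected to give 3800 nM in this assay, most likely falling between 1800 nM and 8000 nM.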

Compound 4, half-maximal inhibitory concentration: 5900 nM
Beside the measured number, compound 4's estimate is 1.6-fold (0.19 log units) below it; the range from low to high includes it.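

In this assay, for the compounds shown here, fluoro in place of chloro on the second core gave a 1.2-fold higher number from compound 3 to compound 4 (0.08 log units; within the scatter) and so produced no step that can be told from repeat-measurement noise. The printed directions of the two steps differ, but that does not amount to a real disagreement between the cores: the same change on two cores in this assay, a 1.4-fold lower number (0.16 log units; within the scatter) from compound 1 to compound 2 and a 1.2-fold higher number (0.08 log units; within the scatter) from compound 3 to compound 4, 1.7-fold (0.23 log units) apart, within the scatter of two such steps. This fits a swap that does little on either core, but it does not show that the two cores respond alike, and a modest difference between them could stay hidden in the scatter.

On these data alone, only chloro and fluoro appear at this place, so it remains open whether a different group there, such as an amine, a carboxylic acid or a longer chain, would move the number beyond the scatter. As far as these compounds go, it is also open whether such a group would act in the same way on the core of compound 1 and on the core of compound 3.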